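Trimming the Oxime Ether of Compound 3

The source may hold more compounds than are shown below. What is called first, only, known or untested is meant among the compounds shown, and "the series" means these compounds.

Compound 3 has the structure `CC/C(=N/OC)c1ccc2oc(CSc3nnc(CNc4ccccc4)n3CC)nc2c1`. In an assay on isolated protein for inhibition of long-chain fatty acid transport protein 1 (Homo sapiens) (a lower number here means a stronger inhibitor, a higher number a weaker inhibitor), compound 3 gives no number, only the assay limit > 1000 nM. Compound 1, `CCc1ccc2oc(CSc3nnc(CNc4ccccc4)n3CC)nc2c1`, is the closest neighbour with a measurement, and in this assay compound 1 also reaches only the limit > 1000 nM. The step that the two limits leave unreadable from compound 1 to compound 3 cannot be read, since both ends are limits rather than numbers. Compound 2, `CCC(=O)c1ccc2oc(CS(=O)(=O)c3nnc(CNc4ccccc4)n3CC)nc2c1`, is the one structure in this set with a real number: in this assay compound 2 gives 1670 nM, a weak inhibition. Two of the three values shown sit at the limit of > 1000 nM in this assay, at which 2 of the 3 values shown sit, so compound 3 stands where most of this set stands, at the edge of what the assay can resolve.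

Compound 4, `CC/C(=N/O)c1ccc2oc(CSc3nnc(CNc4ccccc4)n3CC)nc2c1`, differs from compound 3 in one place: hydrogen in place of methyl on an oxygen. Among the measured compounds shown here, no measured step in this set touches that oxygen, so there is nothing to read a direction from; the only anchor is that every neighbour is weak or unmeasurable. Compound 4 is therefore expected to remain weak, around 2500 nM, with a plausible range from 800 nM to 8000 nM. That estimate amounts to an expected step that the limit leaves unreadable from compound 3 to compound 4, not one beyond the usual scatter.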

Compound 4, half-maximal inhibitory concentration: 260 nM
The estimate for compound 4 lay 9.6-fold (0.98 log units) above the measured number; measured number outside the range, below it.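

Replacing methyl with hydrogen on the oxygen, the change from methoxy to hydroxy, gives the first readable effect at this position in this assay: there is an at least 3.8-fold lower number from compound 3 to compound 4 (0.58 log units; beyond the scatter). Compared with the small ethyl group on the aromatic carbon, the whole hydroxy-bearing group also gives an at least 3.8-fold lower number from compound 1 to compound 4 (0.58 log units; beyond the scatter), so compound 4 has a measurable number where its two closest neighbours reach only a limit. The step from compound 1 to compound 3 cannot be read, and the two readable steps give only a minimum size, because their starting values are limits: the limit of > 1000 nM in this assay, at which 2 of the 4 values shown sit.

From the compounds shown here alone, how an ethoxy group or an amino group on the double-bonded nitrogen would compare with the hydroxy of compound 4 remains open. It is also open whether a carboxylic acid in place of the whole group on that aromatic carbon could match compound 4, so the compounds shown cannot tell whether the gain depends on this particular group.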